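Side-chain variation on the shared amide core

The source may report more compounds than this note shows. Statements on the series, on what has been measured and on what is new or still open speak of the compounds shown alone.

For the measured compounds named here, the series so far holds two compounds. Compound 1 `Cn1c(-c2ccc(NC(=O)CSc3nc4cc(Cl)ccc4o3)cc2)nc(-c2ccccc2)c1-c1ccccc1` in a functional assay on MCF7 cells (Homo sapiens) for cytotoxicity, read by MTT assay, with a stated time of 24 h, tested at 0.64 ug/mL (a higher number here means a stronger effect of the compound at the concentration tested, a lower number a weaker effect), gives 2.4%. Compound 2 `Cn1c(-c2ccc(NC(=O)CSC3=NCCS3)cc2)nc(-c2ccccc2)c1-c1ccccc1` in this assay gives 10.3%. Going by the values given here, compound 2 stands highest of the two numbers, but the only step known, a number 7.9 percentage points higher from compound 1 to compound 2 (within the scatter), lies within the scatter, so no order between the two can be claimed.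

Compound 3 `Cn1c(-c2ccc(NC(=O)CN3CCN(c4ccccc4)CC3)cc2)nc(-c2ccccc2)c1-c1ccccc1` is not yet measured. It differs from compound 2 by a group of 12 heavy atoms (10 carbon, 2 nitrogen; one six-membered non-aromatic ring with 2 hetero atoms, one six-membered aromatic ring of carbon only) in place of a group of 6 heavy atoms (3 carbon, 1 nitrogen, 2 sulfur; one five-membered non-aromatic ring with 2 hetero atoms), on a saturated chain carbon bound to a carbonyl carbon. Among the compounds with values here, no measured step touches this place: the single step known sits on the sulfur, and it was within the scatter. There is therefore no basis for expecting a change beyond the scatter in this assay, and the expected step is a number 0.3 percentage points lower from compound 2 to compound 3 (within the scatter). Compound 3 is estimated at 10%, with a range from 0% to 28%.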

Compound 3, a percentage reported as activity, at one concentration (the size of the read-out at that concentration, not a potency): 12.1%
Compound 3: the middle estimate sits 2.1 percentage points below what was measured; low and high end bracket the measured number.
By their numbers in this assay, from the lowest: compounds 1, 2 and 3 (each within the scatter of the next).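

For the compounds shown here, this is the first measured change on the saturated chain carbon bound to a carbonyl carbon, and in this assay it gives a number 1.8 percentage points higher from compound 2 to compound 3 (within the scatter) and a number 9.7 percentage points higher from compound 1 to compound 3 (within the scatter). The 4-phenylpiperazin-1-yl group, which carries no sulfur, is therefore not separated from either sulfur-bearing group, so the three quite different groups tested at this place give no order. No available evidence bears on this result.

From the compounds shown here alone, whether a morpholin-4-yl ring, a simple dimethylamino group or a carboxylic acid at this place would give a step beyond the scatter remains open. Going by these compounds, since all three values come from a single concentration, how the compounds compare in potency also remains open.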